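A few compounds are considered here, and "the series" means these few. Any claim that something is new, unique, unknown or untested is made for them only; others in the source may bear on it.

Compound 1, `COc1cc(-c2nnc(SCC(=O)c3ccccc3)n2N)cc(OC)c1OC`, in a functional assay on HepG2 cells (Homo sapiens) for antiproliferative activity, read by MTT assay, with a stated time of 48 h; a higher number here means a weaker inhibitor, a lower number a stronger inhibitor: 7800 nM.
Compound 2, `COc1cc(-c2nnc(SCC(=O)c3ccc(Cl)cc3)n2N)cc(OC)c1OC`, in this assay: only a limit, > 100000 nM.

Compound 2 stands at the edge of what this assay reports, since its value is the limit of > 100000 nM in this assay, at which 1 of the 2 values shown sits. Among the compounds with values here, the one measured step, an at least 12-fold higher number from compound 1 to compound 2 (1.10 log units; beyond the scatter), is large and beyond the scatter. Compound 3, `COc1cc(-c2nnc(SCC(=O)Nc3ccccc3F)n2N)cc(OC)c1OC`, differs from compound 2 by (2-fluorophenyl)amino in place of 4-chlorophenyl on a carbonyl carbon. Within the data shown here, that measured step bears on this change only in part: the 4-chlorophenyl that leaves carries the chloro whose arrival made the number from compound 1 to compound 2 rise, but what enters, the (2-fluorophenyl)amino, has no counterpart among the measured compounds. On these data alone, because compound 2 sits at the limit of > 100000 nM in this assay, at which 1 of the 2 values shown sits, the true size of any step from it is unknown. The expected step is an at least 5.0-fold lower number from compound 2 to compound 3 (0.69 log units; beyond the scatter), a fall in the number. Compound 3 is therefore estimated at 20000 nM, within 4000 nM to 100000 nM.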

Compound 3, half-maximal inhibitory concentration: 18700 nM
The estimate for compound 3 lay 1.1-fold (0.03 log units) above the measured number; the measured number falls inside the stated range.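

In this assay, within the data shown here, the carbonyl carbon, which held only phenyl and 4-chlorophenyl in the earlier compounds, now carries (2-fluorophenyl)amino, and compound 3 gives a number within the range of the assay. Set against the phenyl of compound 1, the new group gives a 2.4-fold higher number from compound 1 to compound 3 (0.38 log units; beyond the scatter), a modest step, so the amide stays on the weaker side of compound 1 while escaping the limit met with 4-chlorophenyl. The other step reads an at least 5.3-fold lower number from compound 2 to compound 3 (0.72 log units; beyond the scatter), which is a bound and no more, since compound 2 holds only a limit: the limit of > 100000 nM in this assay, at which 1 of the 3 values shown sits.

The compounds shown leave open how much of the change from compound 1 belongs to the amide hydrogen and how much to the fluorine, which a plain phenylamino group on the same carbonyl carbon would separate. Equally open, on these data alone, is how a saturated amine such as piperidine would read at this carbon.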